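From 3-hydroxypiperidin-1-yl to 4-hydroxypiperidin-1-yl in compound 3

The source may report more compounds than this note shows. Statements on the series, on what has been measured and on what is new or still open speak of the compounds shown alone.

Measured in a functional assay on HCT-116 cells (Homo sapiens) for cytotoxicity, read by MTT assay, with a stated time of 72 h; a higher number here means a weaker inhibitor, a lower number a stronger inhibitor:
- Compound 1 `Cc1ccc(S(=O)(=O)c2nc3ccccc3nc2N2CCCC2)cc1`: > 50000 nM (a limit, not a number)
- Compound 2 `Cc1ccc(S(=O)(=O)c2nc3ccccc3nc2N2CCc3ccccc3C2)cc1`: 39000 nM
- Compound 3 `Cc1ccc(S(=O)(=O)c2nc3ccccc3nc2N2CCCC(O)C2)cc1`: 3270 nM

Compound 3 holds the lowest number of the series. Compound 4 `Cc1ccc(S(=O)(=O)c2nc3ccccc3nc2N2CCC(O)CC2)cc1` has the same atoms, joined differently: 4-hydroxypiperidin-1-yl in place of 3-hydroxypiperidin-1-yl on an aromatic carbon. The group still sits on an aromatic carbon, next to the ring nitrogen. Within the data shown here, two measured steps bear on this change, both large: an at least 15-fold lower number from compound 1 to compound 3 (1.18 log units; beyond the scatter) and a 12-fold lower number from compound 2 to compound 3 (1.08 log units; beyond the scatter). Among the measured compounds shown here, neither tests the new group directly, so they show only that changes at this place can matter in this assay. For the measured compounds named here, with compound 3 at 3270 nM, the lowest number so far, a modest move towards a higher number is expected. The expected change is a 1.5-fold higher number from compound 3 to compound 4 (0.18 log units; within the scatter). For compound 4 the estimated value is 5000 nM, with an expected range of 1500 nM to 20000 nM.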

Compound 4, half-maximal inhibitory concentration: 5440 nM
Compound 4: middle estimate off by 1.1-fold (0.04 log units), on the low side; the measured number falls inside the stated range.
By their numbers in this assay, from the lowest: compounds 3 and 4 (each within the scatter of the next); then compound 2. At a limit, above all of these: compound 1.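

In this assay, the two hydroxypiperidine groups cannot be told apart, with a 1.7-fold higher number from compound 3 to compound 4 (0.22 log units; within the scatter). So the lower numbers are not tied to 3-hydroxypiperidin-1-yl alone: 4-hydroxypiperidin-1-yl also stands apart from the other two groups, with a 7.2-fold lower number from compound 2 to compound 4 (0.86 log units; beyond the scatter) and an at least 9.1-fold lower number from compound 1 to compound 4 (0.96 log units; beyond the scatter). The last of these steps is only a floor, as the value of compound 1 is a limit: the limit of > 50000 nM in this assay, at which 1 of the 4 values shown sits.

The compounds shown leave open how a plain piperidine, or a piperidine carrying an amine or a methoxy group in place of the hydroxyl, would compare on this aromatic carbon.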